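The source may hold more compounds than are shown below. What is called first, only, known or untested is meant among the compounds shown, and "the series" means these compounds.

Three compounds sharing one core were tested in a functional assay on MCF7 cells (Homo sapiens) for cytotoxicity, with a stated time of 48 h; a lower number here means a stronger inhibitor, a higher number a weaker inhibitor. Compound 1 `O=[N+]([O-])c1ccc(CN2CCC(n3cc(CC(OCc4cc(-c5cccc(Br)c5)no4)c4ccc(Br)cc4)nn3)CC2)cc1` gives 6000 nM, compound 2 `O=[N+]([O-])c1ccc(CN2CCC(n3cc(CC(OCc4cc(-c5cccc(F)c5)no4)c4ccc(Br)cc4)nn3)CC2)cc1` gives 8000 nM, and compound 3 `O=[N+]([O-])c1ccc(CN2CCC(n3cc(CC(OCc4cc(-c5ccccc5Br)no4)c4ccc(Br)cc4)nn3)CC2)cc1` gives 6000 nM. The cores of compound 1 and compound 3 differ by 2-bromophenyl in place of 3-bromophenyl on an aromatic carbon. Going from compound 1 to compound 2 the change is fluoro in place of bromo on an aromatic carbon, and it moved the number by a 1.3-fold higher number from compound 1 to compound 2 (0.12 log units; within the scatter). Compound 4 `O=[N+]([O-])c1ccc(CN2CCC(n3cc(CC(OCc4cc(-c5ccccc5F)no4)c4ccc(Br)cc4)nn3)CC2)cc1` is not yet measured; it carries the change (fluoro in place of bromo on an aromatic carbon). This is the same kind of change as in compound 2, but the place differs: meta to a large group there, ortho to a large group here. Because a 1.3-fold higher number from compound 1 to compound 2 (0.12 log units; within the scatter) stayed within the scatter, the step from compound 3 to compound 4 is expected to be small, about a 1.3-fold higher number from compound 3 to compound 4 (0.10 log units; within the scatter). Compound 4 is therefore estimated at 7500 nM, with a likely range from 4000 nM to 14000 nM.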

Compound 4, half-maximal inhibitory concentration: 8000 nM
Compound 4: middle estimate off by 1.1-fold (0.03 log units), on the low side, within the range that was stated.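

In this assay, the step for fluoro in place of bromo on the second core is a 1.3-fold higher number from compound 3 to compound 4 (0.12 log units; within the scatter), and it matches the same change on the first core: the same change on two cores in this assay, a 1.3-fold higher number (0.12 log units; within the scatter) from compound 1 to compound 2 and a 1.3-fold higher number (0.12 log units; within the scatter) from compound 3 to compound 4, 1.0-fold (0.00 log units) apart, within the scatter of two such steps. The other two steps, no change at the digits printed from compound 2 to compound 4 (within the scatter) and a 1.3-fold higher number from compound 1 to compound 4 (0.12 log units; within the scatter), also lie within the scatter. The change therefore carried between these two cores without a visible difference, but this does not show that it has a real effect on either core, and a small step repeated within the scatter cannot establish transferability for larger effects.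

The compounds shown leave open whether a methoxy group or an amine at this place would move the number beyond the scatter. They also leave open whether the step would stay the same with an amine in place of the nitro group.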